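The source may hold more compounds than are shown below. What is called first, only, known or untested is meant among the compounds shown, and "the series" means these compounds.

Compound 1, `COc1cc(-c2cc(/C=C/C(=O)c3ccc(N)cc3)[nH]n2)cc(OC)c1OC`: -66%
Compound 2, `COc1cc(-c2cc(/C=C/C(=O)c3ccc(Cl)c(Cl)c3)[nH]n2)cc(OC)c1OC`: 16%

In a functional assay on OVCAR-5 cells (Homo sapiens) for cytotoxicity, read by sulforhodamine B assay, with a stated time of 48 h, tested at 100 uM (a lower number here means a stronger effect, a higher number a weaker effect of the compound at the concentration tested), compound 1 gives -66%, the lowest of the two numbers; the nearest is compound 2 with 16%, and the change between them is a number 82 percentage points higher from compound 1 to compound 2 (beyond the scatter). Compound 3, `COc1ccc(-c2cc(/C=C/C(=O)c3ccc(N)cc3)[nH]n2)cc1OC`, differs from compound 1 at another place: hydrogen in place of methoxy on an aromatic carbon. Among the measured compounds shown here, no measured step touches this change, so the one known step offers no guide, and the expectation for compound 3 rests on compound 1 alone. The step from compound 1 to compound 3 is expected to be a number 26 percentage points higher from compound 1 to compound 3 (beyond the scatter), toward a somewhat weaker effect. Compound 3 is therefore estimated at -40%, within -90% to 15%.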

Compound 3, a percentage reported as activity, at one concentration (the size of the read-out at that concentration, not a potency): -81%
The estimate for compound 3 lay 41 percentage points above the measured number; low and high end bracket the measured number.
By their numbers in this assay, from the lowest: compound 3; then compound 1; then compound 2.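

Replacing this methoxy with hydrogen does not cost activity: in this assay, the change gives a number 15 percentage points lower from compound 1 to compound 3 (beyond the scatter), a modest shift toward a stronger effect. The shared core therefore keeps its strong effect at the concentration tested without this methoxy on the aromatic carbon. No available evidence explains the shift. The compounds shown leave open whether a hydroxyl group or a fluorine atom on this carbon would match hydrogen. They also leave open whether the same change would have a similar effect alongside the 3,4-dichlorophenyl group of compound 2.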